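A few compounds are considered here, and "the series" means these few. Any claim that something is new, unique, unknown or untested is made for them only; others in the source may bear on it.

Among the compounds with values here, in a functional assay on K562 cells (Homo sapiens) for inhibition, read by trypan blue exclusion, with a stated time of 72 h (on this read-out lower numbers stand for stronger inhibition and higher numbers for weaker inhibition), compound 1 `Cn1c(=O)c(S(=O)(=O)c2ccccc2)cc2cnc(Nc3ccc4ncccc4c3)nc21` gives 100000 nM, the highest of the three numbers so far. Compound 2 `Cn1c(=O)c(S(=O)(=O)c2ccccc2)cc2cnc(Nc3cnc4[nH]ccc4c3)nc21` gives 5000 nM, and compound 3 `Cc1cc2cc(Nc3ncc4cc(S(=O)(=O)c5ccc(F)cc5F)c(=O)n(C)c4n3)ccc2[nH]1` gives 750 nM. Compound 4 `Cc1ccc(S(=O)(=O)c2cc3cnc(Nc4ccc5ncccc5c4)nc3n(C)c2=O)cc1` differs from compound 1 by methyl in place of hydrogen on an aromatic carbon, turning phenylsulfonyl into (4-methylphenyl)sulfonyl. Within the data shown here, the only single-place step measured, a 20-fold lower number from compound 1 to compound 2 (1.30 log units; beyond the scatter), is large, but it changes a different group and leaves the phenylsulfonyl untouched, so it gives no size for this change. Among the measured compounds shown here, with no measured step at this place, the expected result in this assay is no change beyond the scatter, an estimated 1.3-fold lower number from compound 1 to compound 4 (0.10 log units; within the scatter). The estimate for compound 4 is 80000 nM, with an expected range of 25000 nM to 200000 nM.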

Compound 4, half-maximal inhibitory concentration: 10000 nM
Estimate against measurement, compound 4: 8.0-fold (0.90 log units) above, and the stated range ends above it.
By their numbers in this assay, from the lowest: compound 3; then compounds 2 and 4 (each within the scatter of the next); then compound 1.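

In this assay the methyl gives a 10-fold lower number from compound 1 to compound 4 (1.00 log units; beyond the scatter) and so shows that the phenylsulfonyl group is not a silent place. A single methyl, para to a large group on this ring, moves the number beyond the scatter while the rest of compound 1 stays unchanged. Nothing measured here bears on the reason for this step. On these data alone, whether a chlorine atom, a methoxy group or an amine at the same place would act like methyl stays open. Also open, as far as these compounds go, is whether this step carries over to the core of compound 2.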